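A few compounds are considered here, and "the series" means these few. Any claim that something is new, unique, unknown or untested is made for them only; others in the source may bear on it.

Measured so far in a functional assay (aorta) with Rattus norvegicus as the target (a lower number here means that less compound is needed, a higher number that more compound is needed for the effect), are these:
Compound 1 `CCC(C)NC1=NS(=O)(=O)c2cc(F)ccc2N1` at 39.2 uM
Compound 2 `O=S1(=O)NC(NCC2CC2)=Nc2ccc(Cl)cc21` at 41.2 uM
Compound 3 `C=CCNC1=Nc2ccc(Cl)cc2S(=O)(=O)N1` at 28.9 uM

Compound 3 at 28.9 uM lies within the scatter of both compound 1 and compound 2. Compound 4 `C=CCNC1=Nc2ccc(Br)cc2S(=O)(=O)N1` differs from it by bromo in place of chloro on an aromatic carbon in the shared core, that is, bromo in place of chloro on an aromatic carbon. For the measured compounds named here, the one measured step, a 1.4-fold lower number from compound 2 to compound 3 (0.15 log units; within the scatter) for vinyl in place of cyclopropyl on a saturated chain carbon bound to an amine nitrogen, stayed within the scatter, but it concerns another place, and no measured step exchanges chloro for bromo. No step beyond the scatter is therefore expected in this assay for this change. The expected size is a 1.1-fold lower number from compound 3 to compound 4 (0.05 log units; within the scatter) as an estimate. For compound 4 the estimate is 26 uM with an expected range from 13 uM to 52 uM for repeat measurements.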

Compound 4, concentration for half-maximal effect: 3 uM
Compound 4: the middle estimate sits 8.7-fold (0.94 log units) above what was measured; measured number below the stated range.
By their numbers in this assay, from the lowest: compound 4; then compounds 3, 1 and 2 (each within the scatter of the next).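

In this assay, for the compounds shown here, the halogen on this aromatic carbon of the shared core proves to matter, which the earlier compounds could not show: bromo in place of chloro gives a 9.6-fold lower number from compound 3 to compound 4 (0.98 log units; beyond the scatter), with the rest of the structure unchanged. This is the only step beyond the scatter among the compounds shown, and it rests on this single pair. Nothing available accounts for the size of this step. As far as these compounds go, it remains open whether bromo gives a similar step with the cyclopropyl-bearing chain of compound 2, and how iodo, methyl or trifluoromethyl at this place would compare.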